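A few compounds are considered here, and "the series" means these few. Any claim that something is new, unique, unknown or untested is made for them only; others in the source may bear on it.

Compound 1 `CCC(=O)N1CC2CC(C1)N2` and compound 2 `O=C([C@H]1C[C@@H]1F)N1CC2CC(C1)N2` share one core and differ only in the group on the carbonyl carbon. Among the compounds with values here, in an assay on SH-EP1 cells for displacement of a labelled ligand from Neuronal acetylcholine receptor; alpha4/beta2 (Homo sapiens), read by scintillation counting (a higher number here means a weaker inhibitor, a lower number a stronger inhibitor), compound 1 gives 6 nM, the highest of the two numbers so far, and compound 2 gives 5.4 nM. Putting 2-fluorocyclopropyl in place of ethyl gave a 1.1-fold lower number from compound 1 to compound 2 (0.05 log units; within the scatter), so a substituted three-membered ring at that position left the number essentially unchanged. Compound 3 `C[C@@H]1C[C@H]1C(=O)N1CC2CC(C1)N2` takes a similar step from compound 1: 2-methylcyclopropyl in place of ethyl on a carbonyl carbon. Within the data shown here, the only measured step that bears on this, from compound 1 to compound 2, was within the scatter, and it is the closest comparison available, as it also places a substituted three-membered ring on the carbonyl carbon. For compound 3 no movement beyond the scatter is therefore expected in this assay, no change at the digits printed from compound 1 to compound 3 (within the scatter). Compound 3 is estimated at 6 nM, within a range from 2.5 nM to 15 nM.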

Compound 3, inhibition constant: 1 nM
For compound 3 the middle estimate is 6.0-fold (0.78 log units) above the measured one, outside the stated range (below it).
By their numbers in this assay, from the lowest: compound 3; then compounds 2 and 1 (each within the scatter of the next).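

In this assay a three-membered ring on the carbonyl carbon does not settle the number by itself: 2-methylcyclopropyl in place of ethyl gives a 6.0-fold lower number from compound 1 to compound 3 (0.78 log units; beyond the scatter) while 2-fluorocyclopropyl in compound 2 stayed within the scatter of ethyl. Changing only what the ring carries, 2-methylcyclopropyl in place of 2-fluorocyclopropyl, gives a 5.4-fold lower number from compound 2 to compound 3 (0.73 log units; beyond the scatter) and so the ring's substituent matters at this position, with compound 3 holding the lowest number of the three. No measurement at hand accounts for the gap between these two ring substituents.

Still open, from the compounds shown here alone, is how plain cyclopropyl or a longer chain such as butyl would read at this position, which would help separate the part played by the ring from that of its methyl. Also open, going by these compounds, is whether the mirror-image form of 2-methylcyclopropyl would read the same.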